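Moving the chlorine around the benzyl ring

This account rests on a few compounds, and the source may have more. Where it says the series, first, only, none or still open, it means among the compounds named here.

Of the compounds shown here, three sharing one core have been measured in a functional assay on the whole organism (artery, strain albino) with Rattus norvegicus as the target, with a stated time of 600 min, at a dose of 10 mg/kg by the oral route; a higher number here means more inhibition at the dose given (going by the name of the read-out), a lower number less inhibition. Compound 1 `CC1=C(C(=O)Nc2ccc([N+](=O)[O-])cc2)C(c2ccc(Br)cc2)N=C(SCc2ccccc2)N1` carries an unsubstituted benzyl group on the sulfur and gives 27.2%. Compound 2 `CC1=C(C(=O)Nc2ccc([N+](=O)[O-])cc2)C(c2ccc(Br)cc2)N=C(SCc2ccccc2Cl)N1` adds a chlorine to that ring and gives 9.7%; compound 3 `CC1=C(C(=O)Nc2ccc([N+](=O)[O-])cc2)C(c2ccc(Br)cc2)N=C(SCc2cccc(Cl)c2)N1` adds a chlorine at a different ring position and gives 5.1%. The step of a number 17.5 percentage points lower from compound 1 to compound 2 (beyond the scatter) and the step of a number 22.1 percentage points lower from compound 1 to compound 3 (beyond the scatter) are both beyond the scatter, whereas the step of a number 4.6 percentage points lower from compound 2 to compound 3 (within the scatter) is within it. Compound 3 therefore holds the smallest number of the three, with compound 2 close to it and compound 1 clearly higher.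

Compound 4 `CC1=C(C(=O)Nc2ccc([N+](=O)[O-])cc2)C(c2ccc(Br)cc2)N=C(SCc2ccc(Cl)cc2)N1` has not been measured. It differs from compound 3 only in this way: 4-chlorophenyl in place of 3-chlorophenyl on a saturated chain carbon bound to a sulfur. For the measured compounds named here, the one measured step that most resembles this change, moving the chlorine from one ring position to another, is a number 4.6 percentage points lower from compound 2 to compound 3 (within the scatter), which stayed within the scatter. Both chlorinated compounds, compound 2 and compound 3, sit low. On that basis the step of a number 2.9 percentage points higher from compound 3 to compound 4 (within the scatter) is expected to be small and within the scatter. Compound 4 is estimated at 8%, with a range from 0% to 22% in this assay.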

Compound 4, a percentage reported as inhibition, in the whole organism at one dose (the size of the read-out at that dose, not a potency): 34.4%
Compound 4: the middle estimate sits 26.4 percentage points below what was measured; the whole stated range lies below it.
By their numbers in this assay, from the lowest: compounds 3 and 2 (each within the scatter of the next); then compounds 1 and 4 (each within the scatter of the next).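

In this assay, the place of the chlorine on the benzyl ring matters: 4-chlorophenyl in place of 3-chlorophenyl gives a number 29.3 percentage points higher from compound 3 to compound 4 (beyond the scatter), and 4-chlorophenyl in place of 2-chlorophenyl gives a number 24.7 percentage points higher from compound 2 to compound 4 (beyond the scatter), so the position that had not yet been tested separates itself from the other two. The earlier compounds shown here could be read as saying that any chlorine on this ring lowers the number, but compounds 2 and 3 fit that reading and compound 4 goes against it: adding the chlorine as 4-chlorophenyl gives a number 7.2 percentage points higher from compound 1 to compound 4 (within the scatter), which leaves the unsubstituted benzyl group and the 4-chlorobenzyl group indistinguishable here. The outgoing and incoming groups contain the same atoms, so these steps track only where the chlorine is joined to the ring.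

Why the result depends on the chlorine's place cannot be said, as no supporting data on that question are available. On these data alone, it also remains open whether a methoxy group or an amine in place of the chlorine of the 4-chlorobenzyl group would keep the number at this level, or whether a longer chain between the sulfur and the ring would.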